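From 2-fluoropyridin-3-yl to 4-ethylphenyl on a sulfonyl sulfur

The source may report more compounds than this note shows. Statements on the series, on what has been measured and on what is new or still open speak of the compounds shown alone.

Three sulfonamides have been tested in an ADME assay on HCT-116 cells (Homo sapiens) for cytotoxicity, read by CellTiter-Glo, with a stated time of 72 h; a lower number here means a stronger inhibitor, a higher number a weaker inhibitor. Compound 1 `Cc1cc(C)c(S(=O)(=O)N2CCN(C3CN4CCC3CC4)CC2)c(C)c1` gave > 5000 nM, which is a limit of this assay rather than a measured number. Compound 2 `COc1ccccc1-c1cccc(S(=O)(=O)N2CCC(N3CCC(C)CC3)CC2)c1` likewise gave only a limit, > 5000 nM. Compound 3 `CC1CCN(C2CCN(S(=O)(=O)c3cccnc3F)CC2)CC1` returned > 10000 nM, again a limit and not a number. Compound 3 therefore stands at the limit of > 10000 nM in this assay, at which 1 of the 3 values shown sits. The other two values sit at the limit of > 5000 nM in this assay, at which 2 of the 3 values shown sit. None of the three compounds shows a measurable effect on the growth of these cells within the tested range.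

Compound 4 `CCc1ccc(S(=O)(=O)N2CCC(N3CCC(C)CC3)CC2)cc1` has not yet been measured. It differs from compound 3 in a single place: 4-ethylphenyl in place of 2-fluoropyridin-3-yl on a sulfonyl sulfur. Within the data shown here, no measured pair in this set carries that change, so the expectation rests on the three limits alone. Given that compound 3 sits at the limit of > 10000 nM in this assay, at which 1 of the 3 values shown sits, the step is expected to be a step that the limit leaves unreadable from compound 3 to compound 4, that is, nothing beyond the scatter of this assay. Compound 4 is therefore estimated at 20000 nM, with a likely range from 5000 nM to 100000 nM, and most probably the assay will once more report only a limit.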

Compound 4, half-maximal inhibitory concentration: > 5000 nM
Compound 4: only a limit was reported (the forecaster's own chance of this, stated with the estimate: 85%); the middle value is on the limit's open side.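

Among these compounds, compound 3 and compound 4 each returned only a limit, and no step between them can be read. The compounds shown leave open at what concentration, if any, each would reach half-maximal inhibition, and whether 4-ethylphenyl in place of 2-fluoropyridin-3-yl changes that concentration.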